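A 4-bromobenzyl group in place of isopropyl

The compounds below may be only part of what the source reports. "The series", "measured", "known", "first", "only" and "open" are said of these compounds alone.

Measured so far in an ADME assay on HEK-293T cells (Homo sapiens) for inhibition, read by luminescence, with a stated time of 72 h, tested at 5 uM (on this read-out higher numbers stand for more inhibition of growth at the one concentration tested and lower numbers for less inhibition of growth), for each compound
- compound 1 `C=CS(=O)(=O)NC/C=C/c1cc(OC)cc(O)c1C(=O)OC(C)C` gives 0.1% here
- compound 2 `C=CS(=O)(=O)NC/C=C/c1cc(OC)cc(O)c1C(=O)OCC1CCCCC1` gives 31.2% here

Of these two, compound 1 stands lowest, with 0.1% as its number. Compound 3 `C=CS(=O)(=O)NC/C=C/c1cc(OC)cc(O)c1C(=O)OCc1ccc(Br)cc1` has not yet been measured. Its difference from compound 1 is 4-bromobenzyl in place of isopropyl on an oxygen next to a carbonyl group and in words it carries 4-bromobenzyl in place of isopropyl on an oxygen next to a carbonyl group. Among the measured compounds shown here, one measured step bears on this change. With cyclohexylmethyl in place of isopropyl at that same place, the step is a number 31.1 percentage points higher from compound 1 to compound 2 (beyond the scatter) and it is large. For the measured compounds named here, no measured compound carries an aromatic ring at this place, so the size remains uncertain. A large upward step in this assay is nevertheless expected, estimated as a number 27.9 percentage points higher from compound 1 to compound 3 (beyond the scatter) in this single comparison. On that basis, compound 3 is expected to give 28% with 5% to 55% as the estimated range.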

Compound 3, percent growth inhibition at one concentration: 0%
For compound 3 the middle estimate is 28 percentage points above the measured one; the whole stated range lies above it.
By their numbers in this assay, from the lowest: compounds 3 and 1 (each within the scatter of the next); then compound 2.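

Putting 4-bromobenzyl in place of isopropyl on this oxygen gives a number 0.1 percentage points lower from compound 1 to compound 3 (within the scatter) in this assay, so a group with more heavy atoms at this place does not by itself bring inhibition of growth. Between the two larger groups, 4-bromophenyl in place of cyclohexyl gives a number 31.2 percentage points lower from compound 2 to compound 3 (beyond the scatter), which ties the gain seen with compound 2 to the particular group it carries and not merely to the presence of a ring. Nothing at hand accounts for this difference between the two rings.

The compounds shown leave open whether the bromine or the aromatic ring itself separates compound 3 from compound 2, a question that a plain benzyl group would address. On these data alone, it also remains open whether a longer chain with no ring, such as n-hexyl, would fall nearer to compound 1 or to compound 2.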